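The source may report more compounds than this note shows. Statements on the series, on what has been measured and on what is new or still open speak of the compounds shown alone.

Working notes on the series, read in a functional assay on A549 cells (Homo sapiens) for antiproliferative activity, read by sulforhodamine B assay, with a stated time of 48 h; on this read-out lower numbers stand for stronger inhibition and higher numbers for weaker inhibition. Compound 3 (`COc1ccc(/C=C/C(=O)C(=Cc2cc(Br)c(O)c(OC)c2)C(=O)/C=C/c2ccc(OC)cc2OC)c(OC)c1`) gives 1090 nM, which lies within the scatter of compound 2 (`COc1ccc(/C=C/C(=O)C(=Cc2ccc(O)c(F)c2)C(=O)/C=C/c2ccc(OC)cc2OC)c(OC)c1`) at 2070 nM. Compound 1 (`COc1ccc(C=C(C(=O)/C=C/c2cccc(OC)c2OC)C(=O)/C=C/c2cccc(OC)c2OC)cc1OC`) gives 170 nM, a number lower than that of compound 3 by more than the scatter. Compound 1 also carries different outer aryl groups, so it offers no clean comparison for the next change.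

Compound 4 (`COc1ccc(/C=C/C(=O)C(=Cc2ccc(OC)c(O)c2)C(=O)/C=C/c2ccc(OC)cc2OC)c(OC)c1`) has not yet been measured. Its change from compound 3 is 3-hydroxy-4-methoxyphenyl in place of 3-bromo-4-hydroxy-5-methoxyphenyl on a double-bonded chain carbon bound to a double-bonded chain carbon: 3-hydroxy-4-methoxyphenyl in place of 3-bromo-4-hydroxy-5-methoxyphenyl, on a double-bonded chain carbon bound to a double-bonded chain carbon. Among the measured compounds shown here, only one measured step bears on this place: a 1.9-fold lower number from compound 2 to compound 3 (0.28 log units; within the scatter). That exchange also swapped one hydroxy-bearing phenyl for another, and it did not leave the scatter. For the measured compounds named here, one step is thin evidence, and no measured pair isolates the loss of the bromine. No clear shift in either direction is therefore expected in this assay. The estimated move is a 1.2-fold lower number from compound 3 to compound 4 (0.08 log units; within the scatter), which would stay within the scatter. Compound 4 is expected at about 900 nM, with an estimated range of 300 nM to 2700 nM.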

Compound 4, half-maximal inhibitory concentration: 380 nM
Beside the measured number, compound 4's estimate is 2.4-fold (0.37 log units) above it, and the stated range covers the measured number.
By their numbers in this assay, from the lowest: compound 1; then compound 4; then compounds 3 and 2 (each within the scatter of the next).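

At the place on a double-bonded chain carbon bound to a double-bonded chain carbon, the aryl group can shift the number in this assay beyond the scatter: 3-hydroxy-4-methoxyphenyl in place of 3-bromo-4-hydroxy-5-methoxyphenyl gives a 2.9-fold lower number from compound 3 to compound 4 (0.46 log units; beyond the scatter), and in place of 3-fluoro-4-hydroxyphenyl it gives a 5.4-fold lower number from compound 2 to compound 4 (0.74 log units; beyond the scatter). The earlier exchange at this place had shown no such shift, so the 3-hydroxy-4-methoxyphenyl group now separates compound 4 from compounds 2 and 3, which remain within the scatter of each other. No measurement on hand accounts for this shift.

Each exchange changes more than one feature of the ring at once: the step from compound 3 to compound 4 removes the bromine while also rearranging the hydroxy and methoxy groups, so the contribution of each remains unresolved. Going by these compounds, it also remains open whether the gain at this place survives if an amine or a carboxylic acid takes the place of the hydroxy group in the 3-hydroxy-4-methoxyphenyl ring.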